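From methyl to nitro on a shared core

The source may hold more compounds than are shown below. What is called first, only, known or untested is meant among the compounds shown, and "the series" means these compounds.

Compound 1 `CS(=O)(=O)c1ccc2nc(NC(=O)CCCCCCC(=O)NO)sc2c1`: 5.69 ug/mL
Compound 2 `Cc1ccc2nc(NC(=O)CCCCCCC(=O)NO)sc2c1`: 0.53 ug/mL

In a functional assay on PC-3 cells (Homo sapiens) for cytotoxicity (a lower number here means a stronger inhibitor, a higher number a weaker inhibitor), compound 2 stands lowest of the two measured compounds, making it the stronger inhibitor. Compound 3 `O=C(CCCCCCC(=O)Nc1nc2ccc([N+](=O)[O-])cc2s1)NO` differs from it as follows: nitro in place of methyl on an aromatic carbon. In words, nitro takes the place of methyl on an aromatic carbon. For the measured compounds named here, one measured step bears on this change: an 11-fold lower number from compound 1 to compound 2 (1.03 log units; beyond the scatter), a large step with methyl in place of methylsulfonyl. Going by the values given here, with only that step as a guide, replacing the methyl of compound 2 is expected to raise the number, though less certainly than a second example would show. The estimate is a 3.8-fold higher number from compound 2 to compound 3 (0.58 log units; beyond the scatter). For compound 3 the expected value is 2 ug/mL, within an estimated range of 0.5 ug/mL to 8 ug/mL.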

Compound 3, half-maximal inhibitory concentration: 1.28 ug/mL
For compound 3 the middle estimate is 1.6-fold (0.19 log units) above the measured one; the range from low to high includes it.
By their numbers in this assay, from the lowest: compound 2; then compound 3; then compound 1.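

In this assay, nitro places the compound in the middle of the three groups at this aromatic carbon: the change from methyl costs something, at a 2.4-fold higher number from compound 2 to compound 3 (0.38 log units; beyond the scatter), while the change from methylsulfonyl gains, at a 4.4-fold lower number from compound 1 to compound 3 (0.65 log units; beyond the scatter). Replacing methyl has now raised the number with two different groups, so methyl still gives the lowest number, and the size of the rise depends on the group that enters. Nothing available explains this order. On these data alone, it remains open where an amine or a carboxylic acid on this same carbon would fall, and whether any group there could bring the number below that of methyl.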